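A few compounds are considered here, and "the series" means these few. Any claim that something is new, unique, unknown or untested is made for them only; others in the source may bear on it.

Compound 1 `CC1(C)[C@H]2CC[C@]1(C)N(Cc1cn(-c3cccc(F)c3)nn1)C(=O)C2`: 220 nM
Compound 2 `CC1(C)[C@H]2CC[C@]1(C)N(Cc1cn(-c3ccccc3C#N)nn1)C(=O)C2`: 240 nM
Compound 3 `CC1(C)[C@H]2CC[C@]1(C)N(Cc1cn(-c3cccc(O)c3)nn1)C(=O)C2`: 280 nM

In a functional assay on PANC-1 cells (Homo sapiens) for inhibition, read by MTT assay, with a stated time of 24 h (on this read-out higher numbers stand for weaker inhibition and lower numbers for stronger inhibition), the three measured compounds sit together: the step of a 1.1-fold higher number from compound 1 to compound 2 (0.04 log units; within the scatter) and the step of a 1.3-fold higher number from compound 1 to compound 3 (0.10 log units; within the scatter) are both within the scatter, so compound 1 stands level with compounds 2 and 3 on this assay. Compound 4 `COc1cccc(-n2cc(CN3C(=O)C[C@@H]4CC[C@@]3(C)C4(C)C)nn2)c1` differs from compound 1 in one place: methoxy in place of fluoro on an aromatic carbon. For the measured compounds named here, no measured step swaps fluoro for methoxy. The closest comparison is the step of a 1.3-fold higher number from compound 1 to compound 3 (0.10 log units; within the scatter), where hydroxy replaced fluoro on the same aromatic carbon and the number barely moved. Compound 4 is therefore expected to stay close to compound 1, with an estimated step of a 1.2-fold higher number from compound 1 to compound 4 (0.07 log units; within the scatter). The estimate for compound 4 is 260 nM, within a range of 130 nM to 520 nM.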

Compound 4, half-maximal inhibitory concentration: 860 nM
Compound 4: middle estimate off by 3.3-fold (0.52 log units), on the low side, outside the stated range (above it).
By their numbers in this assay, from the lowest: compounds 1, 2 and 3 (each within the scatter of the next); then compound 4.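

Methoxy is the first change at this carbon to move the number in this assay, giving a 3.9-fold higher number from compound 1 to compound 4 (0.59 log units; beyond the scatter), whereas fluoro and hydroxy stood level there. Adding only a methyl to the oxygen of the hydroxy gives a 3.1-fold higher number from compound 3 to compound 4 (0.49 log units; beyond the scatter), and the comparison with the 2-cyanophenyl compound gives a 3.6-fold higher number from compound 2 to compound 4 (0.55 log units; beyond the scatter), so here the methyl on that oxygen goes with weaker inhibition. No supporting measurement explains this shift. On these data alone, whether a longer chain such as ethoxy would weaken inhibition further, or how an amine on the same carbon would behave, stays open.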